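A few compounds are considered here, and "the series" means these few. Any claim that something is new, unique, unknown or untested is made for them only; others in the source may bear on it.

Measured so far in a functional assay on MCF7 cells (Homo sapiens) for antiproliferative activity; on this read-out lower numbers stand for stronger inhibition of growth and higher numbers for weaker inhibition of growth:
- compound 1 `Oc1ccc(-c2nc3cc(F)ccc3s2)cc1O`, this assay 720 nM
- compound 2 `COc1cc(-c2nc3cc(F)ccc3s2)ccc1O`, this assay 750 nM
- compound 3 `COc1cc(-c2nc3cc(F)ccc3s2)cc(OC)c1OC`, this assay 1.9 nM

Compound 1 and compound 2 share a core and differ by one change, (hydrogen in place of methyl on an oxygen on an aromatic ring). The step measured for it is a 1.0-fold lower number from compound 2 to compound 1 (0.02 log units; within the scatter), so within this pair the change leaves the read-out essentially unchanged. Compound 3 carries a different substitution pattern on the same ring; the difference between the core of compound 3 and that of compound 2 is not broken down here. Compound 3 gives the lowest number of the three, and its gap to compound 1 and to compound 2 lies beyond the scatter in both cases.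

Compound 4 `COc1cc(-c2nc3cc(F)ccc3s2)cc(O)c1OC` is not yet measured in this assay. It follows from compound 3 by hydrogen in place of methyl on an oxygen on an aromatic ring. The place of this change reads word for word as in the pair compound 2 to compound 1, so it is the same change, made here on a more substituted ring. On the strength of the earlier step of a 1.0-fold lower number from compound 2 to compound 1 (0.02 log units; within the scatter), a small step is expected for a 1.3-fold higher number from compound 3 to compound 4 (0.12 log units; within the scatter). Compound 4 is therefore estimated at 2.5 nM, with a range from 0.9 nM to 8 nM expected.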

Compound 4, concentration for 50% growth inhibition: 653 nM
Beside the measured number, compound 4's estimate is 260-fold (2.42 log units) below it; the measured number lies above the stated range.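

On the core of compound 3, the change from methoxy to hydroxy gives a 340-fold higher number from compound 3 to compound 4 (2.54 log units; beyond the scatter), so here it is a large loss of growth inhibition in this assay and not the silent change seen on the core of compound 2. Among these compounds, the step therefore does not transfer between these two cores, and the earlier pair is no guide to its size on the more substituted ring: the same change on two cores in this assay, a 1.0-fold lower number (0.02 log units; within the scatter) from compound 2 to compound 1 and a 340-fold higher number (2.54 log units; beyond the scatter) from compound 3 to compound 4, 360-fold (2.55 log units) apart, beyond the scatter of two such steps With only two pairs, this shows that the outcome depends on the core, but it does not show which feature of the core decides it, or how the step would fall on any third core.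

The compounds shown leave open whether the low number of compound 3, 1.9 nM, needs a methoxy group at the place of the change or would survive another group there. An ethoxy group, an amine or a fluorine at that place would test this, and the same groups on the core of compound 2 would show whether the dependence on the core holds beyond the hydroxy.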